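Replacing a phenyl with an ethyl on the ring nitrogen

The compounds below may be only part of what the source reports. "The series", "measured", "known", "first", "only" and "open" are said of these compounds alone.

Of the compounds shown here, three have been measured so far. In a functional assay on SK-MEL-2 cells (Homo sapiens) for inhibition, read by sulforhodamine B assay, with a stated time of 72 h (on this read-out higher numbers stand for weaker inhibition of growth and lower numbers for stronger inhibition of growth), compound 1 `CC(C)(C)OC(=O)NCCCCCNC1=Nc2ccccc2C(CC(=O)NCc2ccccc2)N1c1ccc(-c2ccccc2)cc1` gives 1480 nM, compound 2 `COC(=O)CC1c2ccccc2N=C(Nc2ccc(-c3ccccc3)cc2)N1CCCCCN` gives 1800 nM, and compound 3 `O=C(CC1c2ccccc2N=C(N2CCCCC2)N1c1ccccc1)NCc1ccc(NS(=O)(=O)c2ccc(F)cc2)cc1` gives 1730 nM. Compound 3 holds the second highest of the three numbers, but its gap to compound 2 and its gap to compound 1 both lie within the scatter, so the three values cannot be told apart.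

Compound 4 `CCN1C(N2CCCCC2)=Nc2ccccc2C1CC(=O)NCc1ccc(NS(=O)(=O)c2ccc(F)cc2)cc1` has not yet been measured in this assay. It differs from compound 3 in one place: ethyl in place of phenyl on an amine nitrogen in a ring. Among the compounds with values here, no measured pair isolates this change, so its effect is unknown. The author expects a modest loss of inhibition, with the step of a 1.5-fold higher number from compound 3 to compound 4 (0.18 log units; within the scatter) leaning toward a higher number, though a step within the scatter is nearly as plausible. On that basis compound 4 is estimated at 2600 nM in this assay, with a likely range from 900 nM to 7500 nM.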

Compound 4, concentration for 50% growth inhibition: 17000 nM
Estimate against measurement, compound 4: 6.5-fold (0.82 log units) below; measured number above the stated range.
By their numbers in this assay, from the lowest: compounds 1, 3 and 2 (each within the scatter of the next); then compound 4.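

In this assay the change of phenyl to ethyl on this ring nitrogen gives a 9.8-fold higher number from compound 3 to compound 4 (0.99 log units; beyond the scatter) and thus weakens inhibition of growth. Within the data shown here, the three earlier compounds could not be told apart and offered no pair differing in one place, so they left the role of this position unknown; this pair shows that, with the piperidin-1-yl group and the rest of compound 3 held fixed, the group on this nitrogen matters. Nothing available explains why the loss occurs.

On these data alone, it remains open whether the loss tracks the ring itself or simply its size, which a benzyl, a cyclohexyl or a longer chain on this nitrogen could help separate. As far as these compounds go, it is also open whether the step would be the same size with a morpholine in place of the piperidin-1-yl group.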